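The source may hold more compounds than are shown below. What is called first, only, known or untested is meant among the compounds shown, and "the series" means these compounds.

Working notes on the series. Compound 3 `COc1ccc(-c2nnc(SC/C(=N/O)c3ccccc3)n2-c2ccccc2)cc1OC` gives 78% in a functional assay on the whole organism (strain albino) for inhibition, with Rattus norvegicus as the target, read by paw edema, with a stated time of 5 h, at a dose of 0.28 mmol/kg by the oral route; on this read-out lower numbers stand for less inhibition and higher numbers for more inhibition at the one dose given (going by the name of the read-out). Compound 1 `COc1ccc(-c2nnc(SCC(=O)c3ccccc3)n2-c2ccccc2)cc1OC` gives 59% in this assay. The change between them, (a group of 8 heavy atoms (7 carbon, 1 oxygen; one six-membered aromatic ring of carbon only) in place of a group of 9 heavy atoms (7 carbon, 1 nitrogen, 1 oxygen; one six-membered aromatic ring of carbon only), on a saturated chain carbon bound to a sulfur), moves the read-out by a number 19 percentage points lower from compound 3 to compound 1 (beyond the scatter). Compound 2 `C=CCn1c(SC/C(=N/O)c2ccccc2)nnc1-c1ccc(OC)cc1` gives 57% in this assay. Its core differs from that of compound 3, and the difference between the two cores is not broken down here. Compound 4 `C=CCn1c(SCC(=O)c2ccccc2)nnc1-c1ccc(OC)cc1` is not yet measured in this assay. It is reached from compound 2 by a group of 8 heavy atoms (7 carbon, 1 oxygen; one six-membered aromatic ring of carbon only) in place of a group of 9 heavy atoms (7 carbon, 1 nitrogen, 1 oxygen; one six-membered aromatic ring of carbon only), on a saturated chain carbon bound to a sulfur, the same change at the same place as that from compound 3 to compound 1. Within the data shown here, because the one measured instance of this change gave a number 19 percentage points lower from compound 3 to compound 1 (beyond the scatter), a step of similar size is expected here, a number 16 percentage points lower from compound 2 to compound 4 (beyond the scatter). This rests on a single pair only. For compound 4 the estimate in this assay is 41%, expected to lie between 27% and 57%.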

Compound 4, a percentage reported as inhibition, in the whole organism at one dose (the size of the read-out at that dose, not a potency): 61%
Compound 4: the middle estimate sits 20 percentage points below what was measured; measured number outside the range, above it.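

Benzoyl in place of the oxime group, on a saturated chain carbon bound to a sulfur, gives a number 4 percentage points higher from compound 2 to compound 4 (within the scatter) in this assay, so on this core the change leaves no readable effect. The step therefore does not carry over unchanged from one core to the other: the same change on two cores in this assay, a number 19 percentage points lower (beyond the scatter) from compound 3 to compound 1 and a number 4 percentage points higher (within the scatter) from compound 2 to compound 4, 23 percentage points apart, beyond the scatter of two such steps

Two pairs show only that the outcome of this change depends on the core; they do not show which part of the cores is responsible, or how the step would read on a third core. The compounds shown leave open how a carboxylic acid or an amine on that same chain carbon would read in this assay. They also leave open whether a longer chain between the sulfur and the benzoyl would read differently.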